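Swapping an Acetyl for a Methoxybenzyl on a Chain Amine

The source may hold more compounds than are shown below. What is called first, only, known or untested is meant among the compounds shown, and "the series" means these compounds.

Compound 1 `CCCCCN(CCCCC)C(=O)N1CCN(C(=O)N(c2ccccc2)c2ccccc2)[C@H](C(=O)NCCNC(C)=O)C1` and compound 2 `CCCCCN(CCCCC)C(=O)N1CCN(C(=O)N(c2ccccc2)c2ccccc2)[C@H](C(=O)N(C)CCN(C)Cc2ccccc2OC)C1` share the same core and differ only in the tail of the side chain. In an assay on CHO cells for binding affinity to Substance-P receptor (Homo sapiens) (a higher number here means a weaker inhibitor, a lower number a stronger inhibitor), compound 1 gives 140 nM, the higher of the two numbers at hand. Compound 2 gives 17 nM in this assay, a gap from compound 1 that lies beyond the usual scatter. Compound 3 `CCCCCN(CCCCC)C(=O)N1CCN(C(=O)N(c2ccccc2)c2ccccc2)[C@H](C(=O)NCCNCc2ccccc2OC)C1` is compound 1 with a single change: 2-methoxybenzyl in place of acetyl on an amine nitrogen, in words 2-methoxybenzyl in place of acetyl on an amine nitrogen. Within the data shown here, no measured pair shows exactly this step, so its size can only be judged indirectly. A gain is expected because compound 2 with its own 2-methoxybenzyl gives 17 nM, though compound 2 also carries methyl groups on both nitrogens that compound 3 lacks. The expected step of a 4.0-fold lower number from compound 1 to compound 3 (0.60 log units; beyond the scatter) is therefore a clear fall in the number. Compound 3 is estimated at 35 nM, with a range from 12 nM to 100 nM.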

Compound 3, half-maximal inhibitory concentration: 9 nM
For compound 3 the middle estimate is 3.9-fold (0.59 log units) above the measured one; measured number outside the range, below it.
By their numbers in this assay, from the lowest: compounds 3 and 2 (each within the scatter of the next); then compound 1.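

In this assay, putting 2-methoxybenzyl in place of acetyl on the amine nitrogen of the side chain gives a 16-fold lower number from compound 1 to compound 3 (1.19 log units; beyond the scatter). The earlier pair differed in more than one place, so it could not tie a change in the number to this group alone; this single change shows that the position responds strongly, and compound 3 reaches its low number without the methyl groups that compound 2 carries on its chain nitrogens. The data shown offer no explanation for the size of this step.

As far as these compounds go, it remains open whether the gain rests on the aromatic ring, the methoxy group or the loss of the acetyl carbonyl, which a plain benzyl or a simple ethyl on the same nitrogen could help separate. The separate contribution of each methyl group in compound 2 also cannot be read from these compounds.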